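Replacing isopentyloxy with benzyloxy on the shared core

The source may hold more compounds than are shown below. What is called first, only, known or untested is meant among the compounds shown, and "the series" means these compounds.

Compound 2 `CC(C)CCOc1cc(C(C)(C)C)ccc1CNC(=O)C(C)c1ccc(NS(C)(=O)=O)c(F)c1` gives 0.6 nM in an assay on cells for antagonist activity at transient receptor potential cation channel subfamily V member 1 (Homo sapiens), read by FLIPR and calcium flux, with a stated time of 6 min; a higher number here means a weaker inhibitor, a lower number a stronger inhibitor. Of the two numbers at hand it is the lower, but compound 1 `CC(C(=O)NCc1ccc(C(C)(C)C)cc1N1CCN(c2ccccc2)CC1)c1ccc(NS(C)(=O)=O)c(F)c1` gives 0.8 nM, and the step of a 1.3-fold lower number from compound 1 to compound 2 (0.12 log units; within the scatter) lies within the scatter, so the two compounds cannot be ordered. Compound 3 `CC(C(=O)NCc1ccc(C(C)(C)C)cc1OCc1ccccc1)c1ccc(NS(C)(=O)=O)c(F)c1` differs from compound 2 by phenyl in place of isobutyl on a saturated chain carbon bound to an oxygen on an aromatic ring. Going by the values given here, no measured step bears directly on this exchange; the one measured step, from compound 1 to compound 2, touched the same aromatic carbon with a different substituent and was within the scatter, which shows only that this position tolerates a change of group without a large move in the inhibition constant. The step of a 1.7-fold higher number from compound 2 to compound 3 (0.22 log units; within the scatter) is therefore expected to stay within the scatter, in no particular direction. For compound 3 the expected inhibition constant is 1 nM, with a range from 0.3 nM to 3.5 nM.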

Compound 3, inhibition constant: 2.9 nM
Beside the measured number, compound 3's estimate is 2.9-fold (0.46 log units) below it, within the range that was stated.
By their numbers in this assay, from the lowest: compounds 2 and 1 (each within the scatter of the next); then compound 3.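

In this assay, going by these compounds alone, this position had so far taken isopentyloxy and 4-phenylpiperazin-1-yl with no readable difference, but the exchange of isobutyl for phenyl on the saturated chain carbon bound to the oxygen gives a 4.8-fold higher number from compound 2 to compound 3 (0.68 log units; beyond the scatter), a modest step beyond the scatter. Benzyloxy also separates from 4-phenylpiperazin-1-yl, with a 3.6-fold higher number from compound 1 to compound 3 (0.56 log units; beyond the scatter), so among these three compounds the position does respond to the group it carries, and compound 3 stands alone at the higher number. Nothing available explains this shift.

The compounds shown leave open whether a saturated ring such as cyclohexyl on the same carbon would read with compound 2 or with compound 3. They also leave open what a longer chain, such as phenethyloxy in place of benzyloxy, would give.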